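Pyrazolylmethyl in place of methylpyrrolylmethyl on the amide

The source may hold more compounds than are shown below. What is called first, only, known or untested is meant among the compounds shown, and "the series" means these compounds.

The series is followed in an assay on HEK293 cells for agonist activity at transient receptor potential cation channel subfamily M member 8 (Homo sapiens), read by fluorescence and calcium flux, with a stated time of 15 min; on this read-out higher numbers stand for an effect only at larger amounts of compound and lower numbers for an effect already at smaller amounts. Compound 1, `CCN(Cc1cccn1C)C(=O)COc1ccc(C)cc1`, gives 21300 nM in this assay. Among the three measured compounds this is the second highest number. The nearest value is that of compound 3, `CCN(Cc1cccs1)C(=O)C[C@H](O)c1ccccc1`, which gives 52000 nM in this assay, a higher number and a gap beyond the usual scatter. The furthest value is that of compound 2, `Cc1ccc(OCC(=O)N(Cc2cccs2)CC(C)C)cc1`, which gives 900 nM in this assay, a lower number by a wide margin, also beyond the scatter. Going by the values given here, no pair of these three differs in only one place, so no single step can be read off among them.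

Compound 4, `CCN(Cc1cn[nH]c1)C(=O)COc1ccc(C)cc1`, is not yet measured. It differs from compound 1 in one place: 1H-pyrazol-4-yl in place of 1-methyl-1H-pyrrol-2-yl on a saturated chain carbon bound to an amide-type nitrogen. The change exchanges one five-membered aromatic ring for another and brings in one hydrogen-bond donor. Among the compounds with values here, nothing in the measured set carries a hydrogen-bond donor on this ring, so the step has no direct precedent here. The expected step from compound 1 to compound 4 in this assay is estimated at a 1.5-fold higher number from compound 1 to compound 4 (0.18 log units; within the scatter), a small move towards a higher number that may not exceed the scatter. Compound 4 is therefore expected to give 32000 nM in this assay, with a range of 8000 nM to 130000 nM.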

Compound 4, half-maximal effective concentration: "active" (no number reported)
For compound 4 the study gives words and no number; no gap can be computed for the estimate.
By their numbers in this assay, from the lowest: compound 2; then compound 1; then compound 3.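

In this assay, going by these compounds alone, compound 4 is reported only as active, without a number, so no step from compound 1 at 21300 nM can be read. No measurement shown bears on this result. The compounds shown leave open whether 1H-pyrazol-4-yl in place of 1-methyl-1H-pyrrol-2-yl shifts the number at all, and in which direction.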